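Methyl to Fluoro on the Pendant Ring: A Forecast

The compounds below may be only part of what the source reports. "The series", "measured", "known", "first", "only" and "open" are said of these compounds alone.

Compound 1, `C/C(=C\c1cc(-c2ccccc2)cs1)C(N)=O`: 2680 nM
Compound 2, `C/C(=C\c1nc(-c2ccccc2)cs1)C(N)=O`: 2380 nM
Compound 3, `C/C(=C\c1nc(-c2ccc(C)cc2)cs1)C(N)=O`: > 50000 nM

In a functional assay on MCF7 cells (Homo sapiens) for cytotoxicity, read by CCK-8 assay, with a stated time of 24 h (a higher number here means a weaker inhibitor, a lower number a stronger inhibitor), compound 1 gives 2680 nM and compound 2 gives 2380 nM, two numbers within the scatter of each other. For compound 3 this assay reports only a limit, > 50000 nM, so compound 3 stands apart from the other two as a limit rather than a number. Within the data shown here, the one measured step that bears on the next change is an at least 21-fold higher number from compound 2 to compound 3 (1.32 log units; beyond the scatter), a large loss. Compound 4, `C/C(=C\c1nc(-c2ccc(F)cc2)cs1)C(N)=O`, differs from compound 3 by fluoro in place of methyl on an aromatic carbon. Removing the methyl undoes the change of that step, and fluoro enters in its place. A return of part of that loss is expected: the step of an at least 5.0-fold lower number from compound 3 to compound 4 (0.69 log units; beyond the scatter). Compound 4 is therefore estimated at 10000 nM, with a range from 3000 nM to 50000 nM.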

Compound 4, half-maximal inhibitory concentration: 3300 nM
Beside the measured number, compound 4's estimate is 3.0-fold (0.48 log units) above it; measured number inside the range.
By their numbers in this assay, from the lowest: compounds 2, 1 and 4 (each within the scatter of the next). At a limit, above all of these: compound 3.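

In this assay, fluoro in place of methyl gives an at least 15-fold lower number from compound 3 to compound 4 (1.18 log units; beyond the scatter), so the large loss at this position does not follow from every replacement of hydrogen there. Fluoro in place of hydrogen gives a 1.4-fold higher number from compound 2 to compound 4 (0.14 log units; within the scatter), so this position accepts fluoro without a change beyond the scatter. Compound 3 remains a limit and not a number: the limit of > 50000 nM in this assay, at which 1 of the 4 values shown sits.

Going by these compounds, whether the loss is confined to methyl stays open, since chloro, methoxy or ethyl at this position could fall on either side. The compounds shown also give no reason for the difference between methyl and fluoro.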